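This account rests on a few compounds, and the source may have more. Where it says the series, first, only, none or still open, it means among the compounds named here.

Measured so far in an ADME assay on cells (Peritoneal macrophage cell, Mus musculus) for cytotoxicity, read by trypan blue exclusion, with a stated time of 48 h; a lower number here means that less compound is tolerated, a higher number that more compound is tolerated:
Compound 1 `Cc1ccc2c(c1)[n+]([O-])c(C#N)c(NS(=O)(=O)c1ccc3ccccc3c1)[n+]2[O-]` gives > 245000 nM, which is a limit of the assay and not a number.
Compound 2 `Cc1cc2c(cc1C)[n+]([O-])c(NS(=O)(=O)c1ccc3ccccc3c1)c(C#N)[n+]2[O-]` gives "not determined" (no result reported).
Compound 3 `N#Cc1c(NS(=O)(=O)c2ccccc2[N+](=O)[O-])[n+]([O-])c2ccc(Cl)cc2[n+]1[O-]` gives 6800 nM.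

For the measured compounds named here, compound 3 thus holds the only single number in this assay. One further value is a limit (the limit of > 245000 nM in this assay, at which 1 of the 3 values shown sits), and one further entry carries no number. Going by the values given here, no step between two measured compounds is available from these three. Compound 4 `N#Cc1c(NS(=O)(=O)c2ccc([N+](=O)[O-])cc2)[n+]([O-])c2ccc(Cl)cc2[n+]1[O-]` differs from compound 3 by 4-nitrophenyl in place of 2-nitrophenyl on a sulfonyl sulfur, in words 4-nitrophenyl in place of 2-nitrophenyl on a sulfonyl sulfur. For this change no step beyond the usual scatter is expected in this assay, in either direction. Compound 4 is expected to give 7000 nM in this assay, within 2500 nM to 20000 nM. The expected step is a 1.0-fold higher number from compound 3 to compound 4 (0.01 log units; within the scatter).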

Compound 4, half-maximal cytotoxic concentration: 7900 nM
For compound 4 the middle estimate is 1.1-fold (0.05 log units) below the measured one; measured number inside the range.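

In this assay, for the compounds shown here, setting 4-nitrophenyl in place of 2-nitrophenyl on a sulfonyl sulfur gives a 1.2-fold higher number from compound 3 to compound 4 (0.07 log units; within the scatter), the first step between compounds that differ in one place. On the core of compound 3, this read-out does not separate the two nitrophenyl groups. Nothing at hand bears on the reason for this result.

Still open, on these data alone, is whether an aminophenyl or a carboxylic acid on the phenyl ring at this sulfonyl sulfur would move the number beyond the scatter. As far as these compounds go, whether the two nitrophenyl groups also match on the core of compound 1 stays open too.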